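Chloro to methyl on the shared core: working notes

The compounds below may be only part of what the source reports. "The series", "measured", "known", "first", "only" and "open" are said of these compounds alone.

Measured so far in a functional assay on MCF7 cells (Homo sapiens) for cytotoxicity, read by MTT assay, with a stated time of 24 h; a lower number here means a stronger inhibitor, a higher number a weaker inhibitor:
compound 1 `c1ccc(CNC(c2ccc[nH]2)c2nnc(-c3ccccc3)o2)cc1` gives 216000 nM.
compound 2 `Clc1cccc(-c2nnc(C(NCc3ccccc3)c3ccc[nH]3)o2)c1` gives 56700 nM.
compound 3 `Clc1ccc(-c2nnc(C(NCc3ccccc3)c3ccc[nH]3)o2)cc1` gives 46200 nM.

Compound 3 has the lowest number of the three, though the gap a 1.2-fold lower number from compound 2 to compound 3 (0.09 log units; within the scatter) keeps compound 2 within the scatter of it; only compound 1 stands clearly apart, by a 4.7-fold lower number from compound 1 to compound 3 (0.67 log units; beyond the scatter). Compound 4 `Cc1ccc(-c2nnc(C(NCc3ccccc3)c3ccc[nH]3)o2)cc1` differs from compound 3 by methyl in place of chloro on an aromatic carbon. For the measured compounds named here, no measured step swaps chloro for methyl. Going by the values given here, the steps that bear on it are a 4.7-fold lower number from compound 1 to compound 3 (0.67 log units; beyond the scatter) and a 3.8-fold lower number from compound 1 to compound 2 (0.58 log units; beyond the scatter), both modest gains from adding chloro to the unsubstituted ring of compound 1. Methyl is expected to fall between the hydrogen and chloro cases, so a small rise in number, a 1.5-fold higher number from compound 3 to compound 4 (0.18 log units; within the scatter), is expected in this assay. Compound 4 is estimated at 70000 nM, range 30000 nM to 160000 nM.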

Compound 4, half-maximal inhibitory concentration: 1120000 nM
Estimate against measurement, compound 4: 16-fold (1.20 log units) below; measured number outside the range, above it.
By their numbers in this assay, from the lowest: compounds 3 and 2 (each within the scatter of the next); then compound 1; then compound 4.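

In this assay, swapping chloro for methyl on this aromatic carbon is no minor change: the result is a 24-fold higher number from compound 3 to compound 4 (1.38 log units; beyond the scatter) and, against the other chloro compound, a 20-fold higher number from compound 2 to compound 4 (1.30 log units; beyond the scatter) in a step of similar size. Methyl also does not fall between hydrogen and chloro, giving a 5.2-fold higher number from compound 1 to compound 4 (0.71 log units; beyond the scatter) in the opposite direction to both chloro steps, so the direction of change on this ring depends on the group. Nothing on hand accounts for this reversal.

On these data alone, whether fluoro, methoxy or trifluoromethyl here would follow chloro or methyl stays open.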